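Swapping a Dimethylamino for Pyrrolidinyl on a Triazole Side Chain

The compounds below may be only part of what the source reports. "The series", "measured", "known", "first", "only" and "open" are said of these compounds alone.

Measured compounds:
Compound 1, `Cc1nnc(CN(C)C)n1-c1ccc(Cl)cc1C(=O)c1ccccc1`, gives 45 mg/kg in a functional assay on the whole organism (strain CF-1) for inhibition, with Mus musculus as the target; a lower number here means that less compound is needed, a higher number that more compound is needed for the effect.
Compound 2, `CN(C)CCn1nc(CN(C)C)n(-c2ccc(Cl)cc2C(=O)c2ccccc2)c1=O`, gives only a limit of > 100 mg/kg in this assay, so no number is known for it.

Within the data shown here, compound 1 therefore holds the only real number in this assay; the other result is a limit, as the limit of > 100 mg/kg in this assay, at which 1 of the 2 values shown sits, shows. Among the measured compounds shown here, since the two compounds differ in more than one place, no step between them can be read.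

Compound 3, `Cc1nnc(CN2CCCC2)n1-c1ccc(Cl)cc1C(=O)c1ccccc1`, has not yet been measured. It differs from compound 1 in one place: pyrrolidin-1-yl in place of dimethylamino on a saturated chain carbon bound to an aromatic carbon. The change is a ring in place of an open chain on a saturated chain carbon bound to an aromatic carbon.

For the measured compounds named here, with no measured step to lean on, the expected step of no change at the digits printed from compound 1 to compound 3 (within the scatter) is small, in no clear direction and likely within the usual scatter. Compound 3 is thus estimated at 45 mg/kg, with a range from 20 mg/kg to 100 mg/kg.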

Compound 3, dose for half-maximal effect: 89 mg/kg
The estimate for compound 3 lay 2.0-fold (0.30 log units) below the measured number, within the range that was stated.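

Among these compounds, this is the first step that can be read: this assay shows a 2.0-fold higher number from compound 1 to compound 3 (0.30 log units; within the scatter), with a ring in place of an open chain on a saturated chain carbon bound to an aromatic carbon. At this place, then, the open dimethylamino group is not required for a result of this size, since the pyrrolidin-1-yl ring gives a number that the usual scatter cannot separate from it. Nothing measured here accounts for this result.

As far as these compounds go, whether a six-membered ring such as piperidin-1-yl or morpholin-4-yl, or a simple primary amine, would fit at the same place remains open. Among the compounds shown here, compound 2 differs from both other compounds in more than one place, so no step to it can be read, and its > 100 mg/kg is a limit.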